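Acid dissociation across the shared core: expectation for compound 3

The source may report more compounds than this note shows. Statements on the series, on what has been measured and on what is new or still open speak of the compounds shown alone.

Measured so far:
compound 1 `Cn1cc(O)c(=O)cc1CN1CCCCC1` gives 6.72
compound 2 `CCc1c(O)c(=O)ccn1CCCn1ccnc1` gives 6.47

Both values come from a physicochemical assay for acid dissociation, read by spectrophotometry. Compound 2 stands lowest of the two, but its nearest neighbour, compound 1, lies within the usual scatter, so no order between them is claimed.

Compound 3 `CCc1c(O)c(=O)ccn1CCN(C)C` is not yet measured. It differs from compound 2 thus: dimethylamino in place of (1H-imidazol-1-yl)methyl on a saturated chain carbon, two bonds along the chain from an aromatic nitrogen. For the measured compounds named here, with no comparable pair measured, the step from compound 2 to compound 3 is expected to stay within the scatter, with no direction asserted; the expected step is a number 0.13 log units higher from compound 2 to compound 3 (within the scatter). Compound 3 is estimated at 6.6, in the range 6.2 to 7.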

Compound 3, acid dissociation constant: 7.16
The estimate for compound 3 lay 0.56 log units below the measured number, outside the stated range (above it).
By their numbers in this assay, from the lowest: compounds 2 and 1 (each within the scatter of the next); then compound 3.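

In this assay, for the compounds shown here, this is the first pair that differs in one place, so it gives the first reading of this position. Dimethylamino in place of (1H-imidazol-1-yl)methyl gives a number 0.69 log units higher from compound 2 to compound 3 (beyond the scatter), which shows that a change on this saturated chain carbon can move the read-out. Nothing at hand accounts for the step.

A single pair cannot show whether the step is particular to dimethylamino. As far as these compounds go, whether a morpholine or a carboxylic acid at the same place would move the number in the same direction remains open.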